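The compounds below may be only part of what the source reports. "The series", "measured", "known", "first", "only" and "open" are said of these compounds alone.

Values in a functional assay on MV4-11 cells (Homo sapiens) for inhibition, read by luminescence, with a stated time of 3 days; on this read-out higher numbers stand for weaker inhibition of growth and lower numbers for stronger inhibition of growth:
- compound 1 `CC(=O)N1CCN(C(=O)[C@@H]2CC[C@@H](C)N2C(=O)C2=C(C(C)C)N3C(=N[C@@](C)(c4ccc(Cl)cc4)[C@H]3c3ccc(Cl)cc3)S2)CC1`: 270 nM
- compound 2 `CC[C@@H]1CC[C@@H](C(=O)N2CCN(C(C)=O)CC2)N1C(=O)C1=C(C(C)C)N2C(=N[C@@](C)(c3ccc(Cl)cc3)[C@H]2c2ccc(Cl)cc2)S1`: 130 nM
- compound 3 `CC(=O)N1CCN(C(=O)[C@@H]2CC[C@@H](C)N2C(=O)C2=C(C(C)C)N3C(=N[C@@](C)(c4ccc(Cl)cc4)[C@H]3c3ccc(Cl)cc3)S2)C[C@@H]1C`: 400 nM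

Compound 2 has the lowest number of the three, and so the strongest inhibition of growth. The modest step behind this is a 2.1-fold lower number from compound 1 to compound 2 (0.32 log units; beyond the scatter).

Compound 4 `CC[C@@H]1CC[C@@H](C(=O)N2CCN(C)[C@H](C)C2)N1C(=O)C1=C(C(C)C)N2C(=N[C@@](C)(c3ccc(Cl)cc3)[C@H]2c2ccc(Cl)cc2)S1` keeps the rest of compound 2 and changes one group: 3,4-dimethylpiperazin-1-yl in place of 4-acetylpiperazin-1-yl on a carbonyl carbon.

The measured steps bear on this only in part. The methyl on a saturated ring carbon gave a 1.5-fold higher number from compound 1 to compound 3 (0.17 log units; within the scatter), a small change, and a ring methyl is also present in the entering group. The methyl on the saturated chain carbon is already carried by compound 4, so the step to compound 2 sets the starting level. Among the measured compounds shown here, no measured step replaces the acetyl-bearing group itself, so confidence is low.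

No step beyond the scatter is therefore expected in this assay, in either direction. The expected step is a 1.1-fold lower number from compound 2 to compound 4 (0.03 log units; within the scatter). For compound 4 the estimated value is 120 nM, with an expected range of 40 nM to 360 nM.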

Compound 4, concentration for 50% growth inhibition: 110 nM
The estimate for compound 4 lay 1.1-fold (0.04 log units) above the measured number; the measured number falls inside the stated range.
By their numbers in this assay, from the lowest: compounds 4 and 2 (each within the scatter of the next); then compounds 1 and 3 (each within the scatter of the next).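

In this assay, the carbonyl carbon whose other neighbour is a saturated ring carbon takes 3,4-dimethylpiperazin-1-yl in place of 4-acetylpiperazin-1-yl with a 1.2-fold lower number from compound 2 to compound 4 (0.07 log units; within the scatter), so in this pair the acetyl group is not required to hold the level of compound 2. The earlier steps shown here only added methyl groups and kept the acetyl group throughout, whereas this step replaces the group itself, and the count of hydrogen-bond acceptors stays the same while one defined stereocentre enters. The data shown offer no measured account of why this exchange is tolerated.

Open, going by these compounds, is how 4-methylpiperazin-1-yl, morpholin-4-yl or a piperazine carrying a carboxylic acid would read on this carbonyl carbon. Also open, on these data alone, is whether the two methyl groups of the entering group contribute separately, and whether the opposite configuration at its stereocentre would read the same.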